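This account rests on a few compounds, and the source may have more. Where it says the series, first, only, none or still open, it means among the compounds named here.

Compounds measured so far:
Compound 1 `CCc1cccc(NS(=O)(=O)c2ccc(N3CCNC3=O)cc2)c1`: 730 nM
Compound 2 `O=C1NCCN1c1ccc(S(=O)(=O)Nc2cccc(Br)c2)cc1`: 340 nM

In a functional assay on DU-145 cells (Homo sapiens) for antiproliferative activity, read by sulforhodamine B assay, with a stated time of 48 h (on this read-out higher numbers stand for weaker inhibition and lower numbers for stronger inhibition), compound 2 holds the lower of the two numbers, at 340 nM. Compound 3 `Cc1cc(C)cc(NS(=O)(=O)c2ccc(N3CCNC3=O)cc2)c1` has 3,5-dimethylphenyl in place of 3-bromophenyl on a sulfonamide nitrogen. Within the data shown here, the only measured step that bears on this change is a 2.1-fold lower number from compound 1 to compound 2 (0.33 log units; beyond the scatter), with bromo in place of ethyl on an aromatic carbon. Among the measured compounds shown here, no measured compound carries the 3,5-dimethylphenyl group, so this is weak guidance, but it points to a modest move towards a higher number. The estimated change is a 1.6-fold higher number from compound 2 to compound 3 (0.21 log units; within the scatter). For compound 3, the expected value is 550 nM, with an estimated range of 190 nM to 1600 nM.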

Compound 3, half-maximal inhibitory concentration: 430 nM
Compound 3: middle estimate off by 1.3-fold (0.11 log units), on the high side, and the stated range covers the measured number.
By their numbers in this assay, from the lowest: compounds 2, 3 and 1 (each within the scatter of the next, the first and the last beyond it).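

Set against 3-bromophenyl, 3,5-dimethylphenyl on the sulfonamide nitrogen shows a 1.3-fold higher number from compound 2 to compound 3 (0.10 log units; within the scatter) in this assay, and set against 3-ethylphenyl it shows a 1.7-fold lower number from compound 1 to compound 3 (0.23 log units; within the scatter) in the same read-out. The position therefore accepts this group with neither step beyond the scatter, although the step between the two earlier compounds lay beyond it. Nothing available gives a reason for these numbers. Left open is how the number responds when the phenyl on the sulfonamide nitrogen carries a methoxy group, an amine or a carboxylic acid instead.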